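Swapping a Phenoxy for a Dimethylamino Group

A few compounds are considered here, and "the series" means these few. Any claim that something is new, unique, unknown or untested is made for them only; others in the source may bear on it.

Of the compounds shown here, three with a shared core have been measured in a functional assay on SK-MEL-5 cells (Homo sapiens) for inhibition, read by sulforhodamine B assay, with a stated time of 48 h; on this read-out higher numbers stand for weaker inhibition of growth and lower numbers for stronger inhibition of growth. Compound 1 `COc1cc(C)cc(-c2c(-c3ccnc(-c4ccc(C(C)=O)cc4)c3)cnn2CC#N)c1` gives 1940 nM. Compound 2 `COc1cc(C)cc(-c2nn(CC#N)cc2-c2ccc(-c3cccc(C(C)=O)c3)nc2)c1` gives 1540 nM. Compound 3 `Cc1cc(O)cc(-c2nn(CC#N)cc2-c2ccnc(-c3ccc(Oc4ccccc4)cc3)c2)c1` gives 2930 nM, the highest of the three numbers, yet its gaps to compound 1 and to compound 2 both fall within the usual scatter, so no real difference among them can be claimed.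

Compound 4 `Cc1cc(O)cc(-c2nn(CC#N)cc2-c2ccnc(-c3ccc(N(C)C)cc3)c2)c1` has not been measured. It differs from compound 3 in one place: dimethylamino in place of phenoxy on an aromatic carbon, para to a large group. Within the data shown here, no measured pair shows this kind of change, so there is no direct guide to its effect in this assay. The expectation is a small step, if any, toward weaker inhibition, with the chance that it stays within the scatter. Compound 4 is expected to give 3500 nM, with a likely range from 1200 nM to 10000 nM. This estimate implies a step of a 1.2-fold higher number from compound 3 to compound 4 (0.08 log units; within the scatter).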

Compound 4, concentration for 50% growth inhibition: 1990 nM
Estimate against measurement, compound 4: 1.8-fold (0.25 log units) above, within the range that was stated.
By their numbers in this assay, from the lowest: compounds 2, 1, 4 and 3 (each within the scatter of the next).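

In this assay the swap gives a 1.5-fold lower number from compound 3 to compound 4 (0.17 log units; within the scatter), so no real difference can be claimed between the two groups. This is the first pair among these compounds that differs in one place, and so the first direct look at this position on the outer aromatic ring. Phenoxy, which carries a six-membered aromatic ring, and the smaller dimethylamino, which has no ring, read alike here, and nothing available explains why.

Only these two groups have been compared at this position, so a single pair cannot show how far that likeness extends. On these data alone, a morpholine ring or a carboxylic acid in the same place could still separate from them, and it remains open whether either would move the number beyond the scatter.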